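The source may report more compounds than this note shows. Statements on the series, on what has been measured and on what is new or still open speak of the compounds shown alone.

Measured compounds:
compound 1 `CNc1cc(Oc2ccc(NC(=O)Nc3ccccc3)cc2)ncn1` gives 6300 nM
compound 2 `CNc1cc(Oc2ccc(NC(=O)Nc3cccc(C(F)(F)F)c3)c(F)c2F)ncn1` gives 20 nM
compound 3 `CNc1nccc(Oc2ccc(NC(=O)Nc3cccc(C(F)(F)F)c3)cc2)n1` gives 50 nM

All three values come from an assay on isolated protein for inhibition of serine/threonine-protein kinase TNNI3K (Homo sapiens); a higher number here means a weaker inhibitor, a lower number a stronger inhibitor. Among them compound 1 stands highest and is the weakest inhibitor of the set; compound 3 is the nearest of the other two and compound 2 the furthest, and both gaps lie well beyond the scatter. Going by the values given here, compounds 2 and 3 each carry a trifluoromethyl group on the terminal phenyl ring alongside other changes elsewhere in the molecule, so no single step between measured compounds isolates any one of those changes.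

Compound 4 `CNc1cc(Oc2ccc(NC(=O)Nc3cccc(C)c3)cc2)ncn1` is not yet measured in this assay. It differs from compound 1 in one place: methyl in place of hydrogen on an aromatic carbon. The group enters on an aromatic carbon of a six-membered aromatic ring of carbon only, meta to a large group; compounds 2 and 3 carry a trifluoromethyl group on that same ring. The step from compound 1 to compound 4 is expected to run downward, toward a stronger inhibitor, but to be modest in size, since the entering methyl is a single carbon and the large gains of compounds 2 and 3 over compound 1 also involve other changes. The expected step is a 4.2-fold lower number from compound 1 to compound 4 (0.62 log units; beyond the scatter). Compound 4 is estimated at 1500 nM, with a range from 400 nM to 5000 nM.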

Compound 4, half-maximal inhibitory concentration: 1260 nM
The estimate for compound 4 lay 1.2-fold (0.08 log units) above the measured number, within the range that was stated.
By their numbers in this assay, from the lowest: compound 2; then compound 3; then compound 4; then compound 1.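

In this assay, the terminal phenyl ring now has a step that can be read on its own: methyl in place of hydrogen on an aromatic carbon, meta to a large group, gives a 5.0-fold lower number from compound 1 to compound 4 (0.70 log units; beyond the scatter), with the rest of the molecule unchanged. Going by these compounds alone, compounds 2 and 3 could not show this, as each differs from compound 1 in more than one place, so this is the first direct sign that a substituent at this position alone moves the number beyond the scatter, even when that substituent is a single carbon. No measurement at hand bears on why the step occurs.

As far as these compounds go, what remains open is how much of the lower numbers of compounds 2 and 3 belongs to the trifluoromethyl group, since in both it comes with other changes elsewhere in the molecule. Also open, from the compounds shown here alone, is how chlorine, methoxy, an ethyl chain or an amine at this same place would compare with methyl, and whether the step would keep its size on a core carrying those other changes.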